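Trifluoromethyl to dimethylamino: a cytotoxicity estimate

A few compounds are considered here, and "the series" means these few. Any claim that something is new, unique, unknown or untested is made for them only; others in the source may bear on it.

Compound 1 `Cc1cc(NC(=O)Nc2cccc([N+](=O)[O-])c2)c2ccccc2n1`: > 25000 nM, a limit
Compound 2 `Cc1cc(NC(=O)Nc2cccc(C(N)=O)c2)c2ccccc2n1`: > 25000 nM, a limit
Compound 3 `Cc1cc(NC(=O)Nc2cccc(C(F)(F)F)c2)c2ccccc2n1`: 16000 nM

Within the data shown here, in an ADME assay on HEK293 cells (Homo sapiens) for cytotoxicity, with a stated time of 72 h (on this read-out higher numbers stand for an effect only at larger amounts of compound and lower numbers for an effect already at smaller amounts), compound 3 gives the only actual number, 16000 nM. Compound 1 and compound 2 both stop at the limit of > 25000 nM in this assay, at which 2 of the 3 values shown sit.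

Compound 4 `Cc1cc(NC(=O)Nc2cccc(N(C)C)c2)c2ccccc2n1` carries dimethylamino in place of trifluoromethyl on an aromatic carbon. Three measured swaps on that aromatic carbon bear on this change: a step that the two limits leave unreadable from compound 1 to compound 2, an at least 1.5-fold lower number from compound 1 to compound 3 (0.19 log units; that floor lies within the scatter) and an at least 1.5-fold lower number from compound 2 to compound 3 (0.19 log units; that floor lies within the scatter). None of them shows a step certain to exceed the scatter. The expected result in this assay is therefore no step beyond the scatter, an estimated 1.3-fold higher number from compound 3 to compound 4 (0.10 log units; within the scatter). Compound 4 is estimated at 20000 nM, with an expected range of 9000 nM to 25000 nM.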

Compound 4, half-maximal effective concentration: > 25000 nM
Compound 4: no number, only a limit (the forecaster's own chance of this, stated with the estimate: 45%); at least 1.2-fold (0.09 log units) between middle value and limit.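

In this assay, compound 4, with dimethylamino on this aromatic carbon, gives > 25000 nM, which is a limit and not a number. Replacing trifluoromethyl with dimethylamino gives an at least 1.5-fold higher number from compound 3 to compound 4 (0.19 log units; that floor lies within the scatter), so a step beyond the scatter is neither shown nor ruled out, and the steps to compound 4 from compound 1 and compound 2 cannot be read. Trifluoromethyl remains the only group here with an actual number, and the other three groups share one ceiling: the limit of > 25000 nM in this assay, at which 3 of the 4 values shown sit.

As far as these compounds go, how far past that limit the three limited compounds lie stays open. Also open, from the compounds shown here alone, is whether a carboxylic acid or a primary amine on this aromatic carbon would give an actual number.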